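Amide variation in an alkyne-linked aryl series

The source may hold more compounds than are shown below. What is called first, only, known or untested is meant among the compounds shown, and "the series" means these compounds.

Measured compounds:
compound 1 `O=C(c1ccc(C#Cc2ccc(Oc3ccccc3)cc2)cc1)N1CCC[C@@H](CO)C1` in a functional assay on TREX cells for negative allosteric modulation of metabotropic glutamate receptor 3 (Rattus norvegicus), read by calcium flux, with a stated time of 2.5 min (on this read-out lower numbers stand for stronger inhibition and higher numbers for weaker inhibition), gives a limit, > 10000 nM.
compound 2 `COc1ccc(C#Cc2ccc(C(=O)N3CCCC(OC)C3)cc2)cc1` in this assay gives 5500 nM.

Among the measured compounds shown here, compound 2 is the only compound in this set with an actual number in this assay; the other entry is a limit, (the limit of > 10000 nM in this assay, at which 1 of the 2 values shown sits), so no step between measured compounds can be drawn and no size of effect for any structural change is established here.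

Compound 3 `COc1ccc(C#Cc2ccc(C(=O)N3CC4CCC(O)C4C3)cc2)cc1` keeps the shared core of compound 2 and differs only at the amide: a group of 9 heavy atoms (7 carbon, 1 nitrogen, 1 oxygen; one five-membered non-aromatic ring of carbon only, one five-membered non-aromatic ring with 1 hetero atom) in place of a group of 8 heavy atoms (6 carbon, 1 nitrogen, 1 oxygen; one six-membered non-aromatic ring with 1 hetero atom), on a carbonyl carbon, in words a group of 9 heavy atoms (7 carbon, 1 nitrogen, 1 oxygen; one five-membered non-aromatic ring of carbon only, one five-membered non-aromatic ring with 1 hetero atom) in place of a group of 8 heavy atoms (6 carbon, 1 nitrogen, 1 oxygen; one six-membered non-aromatic ring with 1 hetero atom), on a carbonyl carbon.

With nothing measured to calibrate the change, the step from compound 2 is expected to be small, a 1.1-fold higher number from compound 2 to compound 3 (0.04 log units; within the scatter), in no fixed direction beyond the scatter. Compound 3 is estimated at 6000 nM, in the range 2000 nM to 20000 nM, with a fair chance that only a limit is returned.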

Compound 3, half-maximal inhibitory concentration: 5500 nM
The estimate for compound 3 lay 1.1-fold (0.04 log units) above the measured number; measured number inside the range.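

Working notes: the amide place, on a carbonyl carbon whose other neighbour is an aromatic carbon, now has its first readable step in this assay. Replacing 3-methoxypiperidin-1-yl with the group of 9 heavy atoms, which has one five-membered non-aromatic ring of carbon only and one five-membered non-aromatic ring with 1 hetero atom, gives no change at the digits printed from compound 2 to compound 3 (within the scatter). This single pair shows that, on this core, going from one six-membered non-aromatic ring to these two five-membered rings, and from 0 to 1 hydrogen-bond donor, leaves the read-out within the scatter. Compound 1 gives a limit, not a number, and steps involving it cannot be read: the limit of > 10000 nM in this assay, at which 1 of the 3 values shown sits.

Among the compounds shown here, still open is whether any amide group on this core shifts the number beyond the scatter, as the one readable step rests on a single pair. A piperidine carrying a carboxylic acid or a primary amine in place of the methoxy group, or an open-chain dimethylamide, would test how far this place stays flat in this assay.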